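A few compounds are considered here, and "the series" means these few. Any claim that something is new, unique, unknown or untested is made for them only; others in the source may bear on it.

Values in a functional assay on MIA PaCa-2 cells (Homo sapiens) for inhibition, read by MTT assay; on this read-out lower numbers stand for stronger inhibition and higher numbers for weaker inhibition:
Compound 1 `O=C(c1cc2cnc(Nc3ccc(N4CCNCC4)cn3)nc2n1C1CCCC1)N1CCCCC1`: 39600 nM
Compound 2 `O=C(Nc1ccccc1)c1cc2cnc(Nc3ccc(N4CCNCC4)cn3)nc2n1C1CCCC1`: 2800 nM

Compound 2 has the lower number of the two, meaning the stronger inhibition. Compound 3 `O=C(Nc1ccc[n+]([O-])c1)c1cc2cnc(Nc3ccc(N4CCNCC4)cn3)nc2n1C1CCCC1` keeps the rest of compound 2 and changes only the ring on the amide-type nitrogen: a group of 7 heavy atoms (5 carbon, 1 nitrogen, 1 oxygen; one six-membered aromatic ring with 1 hetero atom) in place of a group of 6 heavy atoms (6 carbon; one six-membered aromatic ring of carbon only), on an amide-type nitrogen. For the measured compounds named here, the one measured step that bears on this, a 14-fold lower number from compound 1 to compound 2 (1.15 log units; beyond the scatter), is large, but it put anilino in place of piperidin-1-yl on a carbonyl carbon. It does not test this ring swap, so no step beyond the scatter is expected in this assay. The expected step is a 1.3-fold higher number from compound 2 to compound 3 (0.10 log units; within the scatter). For compound 3 the estimated value is 3500 nM, with an expected range of 1000 nM to 12000 nM.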

Compound 3, half-maximal inhibitory concentration: 125000 nM
For compound 3 the middle estimate is 36-fold (1.55 log units) below the measured one, outside the stated range (above it).
By their numbers in this assay, from the lowest: compound 2; then compound 1; then compound 3.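

In this assay, the ring on the amide-type nitrogen matters a great deal: there is a 45-fold higher number from compound 2 to compound 3 (1.65 log units; beyond the scatter) when the group of 7 heavy atoms replaces phenyl. The same group also falls behind piperidin-1-yl, with a 3.2-fold higher number from compound 1 to compound 3 (0.50 log units; beyond the scatter) between the two amides, so the gain seen with anilino does not carry over to every aromatic ring at this place. No measurement given here accounts for this loss.

Going by these compounds, whether the ring nitrogen alone or the oxygen on it goes with the loss stays open. Also open, on these data alone, is how a pyridin-3-yl or 4-methoxyphenyl group would behave on this nitrogen.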